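The source may hold more compounds than are shown below. What is called first, only, known or untested is meant among the compounds shown, and "the series" means these compounds.

Compound 3 `CC1=CC[C@H](C(C)C)c2cc(C)c(OC(=O)c3ccc([N+](=O)[O-])cc3)cc21` is one of three compounds tested in a functional assay on HCT-15 cells (Homo sapiens) for antiproliferative activity, read by sulforhodamine B assay, with a stated time of 48 h, tested at 50 uM; a lower number here means less inhibition, a higher number more inhibition at the concentration tested (going by the name of the read-out). Compound 2 `CC1=CC[C@H](C(C)C)c2cc(C)c(OC(=O)Nc3ccccc3)cc21` gives 92%, while compound 3 gives 67.8%, the lower of the two numbers reported. Compound 1 `Cc1cc2c(C(C)C)ccc(C)c2cc1OC(=O)c1cccc(C(F)(F)F)c1`, built on a different core, was reported as "not active" (no number reported) without any number. For the measured compounds named here, the only step that can be read is a number 24.2 percentage points lower from compound 2 to compound 3 (beyond the scatter). That exchange sits at the carbonyl carbon rather than on the aromatic ring itself. Compound 4 `CC1=CC[C@H](C(C)C)c2cc(C)c(OC(=O)c3ccc(Cl)cc3)cc21` differs from compound 3 by chloro in place of nitro on an aromatic carbon. Going by the values given here, no measured step shows this same exchange, so the move from compound 3 to compound 4 has no direct anchor; the expectation rests on the modest size of the single step seen and on the standing of compound 3. Compound 4 is therefore estimated to give 60%, with a range from 35% to 85%. That estimate means a step of a number 7.8 percentage points lower from compound 3 to compound 4 (within the scatter), expected to stay within the usual scatter.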

Compound 4, a percentage reported as inhibition, at one concentration (the size of the read-out at that concentration, not a potency): 47.4%
Beside the measured number, compound 4's estimate is 12.6 percentage points above it; low and high end bracket the measured number.
By their numbers in this assay, from the lowest: compound 4; then compound 3; then compound 2.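

Exchanging nitro for chloro on this aromatic carbon, para to a large group, is not a neutral swap: in this assay it gives a number 20.4 percentage points lower from compound 3 to compound 4 (beyond the scatter). The group on this ring therefore affects the result, as does the exchange at the carbonyl carbon seen earlier. Putting 4-chlorophenyl in place of anilino gives a number 44.6 percentage points lower from compound 2 to compound 4 (beyond the scatter), a larger step than the one seen with 4-nitrophenyl in that same place, and no measurement of any property of these groups is at hand to explain these steps.

Going by these compounds, two groups at this position cannot establish a trend, so how a methoxy group or an amine there would compare remains open. Also open, on these data alone, is whether chloro on the ring of the anilino compound would shift the number in the same direction.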